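Replacing the 3,5-dimethoxyphenyl group of compound 3

This account rests on a few compounds, and the source may have more. Where it says the series, first, only, none or still open, it means among the compounds named here.

In an ADME assay on WI-38 cells (Homo sapiens) for cytotoxicity, read by MTT assay, with a stated time of 72 h (a lower number here means a stronger inhibitor, a higher number a weaker inhibitor), three compounds sharing one core have been measured. Compound 1 `CC(C)c1cccc(NC(=O)CCc2cccc3c2B(O)OC3)c1` gives 22000 nM, compound 2 `O=C(CCc1cccc2c1B(O)OC2)Nc1cccc(-c2cccc(Cl)c2)c1` gives 58000 nM, and compound 3 `COc1cc(OC)cc(-c2cccc(NC(=O)CCc3cccc4c3B(O)OC4)c2)c1` gives 1700 nM, the lowest number of the three.

Compound 4 `O=C(CCc1cccc2c1B(O)OC2)Nc1cccc(-c2ccc(C(F)(F)F)cc2)c1` carries 4-(trifluoromethyl)phenyl in place of 3,5-dimethoxyphenyl on an aromatic carbon. Among the compounds with values here, the nearest precedent is a 34-fold lower number from compound 2 to compound 3 (1.53 log units; beyond the scatter), a large step that puts 3,5-dimethoxyphenyl in place of 3-chlorophenyl. The step of a 13-fold lower number from compound 1 to compound 3 (1.11 log units; beyond the scatter) is also large, whereas a 2.6-fold higher number from compound 1 to compound 2 (0.42 log units; beyond the scatter) is modest and runs the other way. Among these three compounds, the low number appears only with 3,5-dimethoxyphenyl, and compound 4 gives up that group. Its closest comparison is therefore compound 2 at 58000 nM, although a second example of this kind of replacement is lacking. In this assay, a large step towards a higher number is expected, estimated as a 12-fold higher number from compound 3 to compound 4 (1.07 log units; beyond the scatter). Compound 4 is estimated at 20000 nM, with an expected range of 5000 nM to 70000 nM.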

Compound 4, half-maximal inhibitory concentration: 26000 nM
Estimate against measurement, compound 4: 1.3-fold (0.11 log units) below; the measured number falls inside the stated range.
By their numbers in this assay, from the lowest: compound 3; then compounds 1 and 4 (each within the scatter of the next); then compound 2.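

Compound 3 now stands apart from a second aryl compound in this assay: the change gives a 15-fold higher number from compound 3 to compound 4 (1.18 log units; beyond the scatter), so the low number is not shared by both aryl groups that lack the methoxy groups. The two groups without methoxy groups can still be told apart, with a 2.2-fold lower number from compound 2 to compound 4 (0.35 log units; beyond the scatter). A phenyl ring at this position does not by itself bring the number down, as the comparison with the isopropyl compound gives a 1.2-fold higher number from compound 1 to compound 4 (0.07 log units; within the scatter), and among these four compounds only compound 3 goes against that reading.

No measured property is available to account for these differences. On these data alone, whether the low number needs both methoxy groups remains open, as does whether a phenyl ring with one methoxy group, a hydroxyl or an amine would retain it.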